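Adding a Second Fluorine to the Benzyl Amide

The source may hold more compounds than are shown below. What is called first, only, known or untested is meant among the compounds shown, and "the series" means these compounds.

Compound 1 `COc1ccc2c(=O)c(/C=C/C(=O)Nc3ccc(C)cc3)coc2c1`: in a functional assay on A549 cells (Homo sapiens) for inhibition, read by MTT assay, with a stated time of 48 h (on this read-out lower numbers stand for stronger inhibition and higher numbers for weaker inhibition), compound 1 gives 17500 nM.
Compound 2 `COc1ccc2c(=O)c(/C=C/C(=O)NCc3cccc(F)c3)coc2c1`: in this assay compound 2 gives 26900 nM.
Compound 3 `COc1ccc2c(=O)c(/C=C/C(=O)NCc3ccccc3)coc2c1`: in this assay compound 3 gives 11800 nM.

Among the three measured numbers, that of compound 2 is the largest. Against compound 1 the step of a 1.5-fold higher number from compound 1 to compound 2 (0.19 log units; within the scatter) is within the scatter, so those two cannot be ranked. Against compound 3 the step of a 2.3-fold lower number from compound 2 to compound 3 (0.36 log units; beyond the scatter) is beyond the scatter, a modest shift when the fluoro gives way to hydrogen on the aromatic carbon.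

Compound 4 `COc1ccc2c(=O)c(/C=C/C(=O)NCc3ccc(F)cc3F)coc2c1` keeps everything of compound 2 except one change: 2,4-difluorophenyl in place of 3-fluorophenyl on a saturated chain carbon bound to an amide-type nitrogen. For the measured compounds named here, only the step between compound 2 and compound 3 bears on this, and only loosely. It shows that one fluorine on that ring moves the number by a modest amount, but nothing measured here tells how a ring carrying two fluorines in other positions behaves. The expected step is therefore small and without a confident direction, a 1.1-fold lower number from compound 2 to compound 4 (0.05 log units; within the scatter), and could well sit inside the scatter. Compound 4 is estimated at 24000 nM, with a range from 9000 nM to 60000 nM.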

Compound 4, half-maximal inhibitory concentration: 13300 nM
Compound 4: the middle estimate sits 1.8-fold (0.26 log units) above what was measured, within the range that was stated.
By their numbers in this assay, from the lowest: compounds 3, 4, 1 and 2 (each within the scatter of the next, the first and the last beyond it).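

In this assay, for the compounds shown here, the step of a 2.0-fold lower number from compound 2 to compound 4 (0.31 log units; beyond the scatter) lies beyond the scatter, so the 2,4-difluorobenzyl group gives the first evidence that changing the fluorine pattern on this ring, not merely having fluorine there, can shift the number. The step of a 1.1-fold higher number from compound 3 to compound 4 (0.05 log units; within the scatter) is within the scatter, and so is a 1.3-fold lower number from compound 1 to compound 4 (0.12 log units; within the scatter), which means that compound 4 cannot be ranked against either compound and that fluorine on this ring does not always go with a higher number: compound 2 differs from the plain benzyl amide of compound 3, while compound 4 does not. No supporting data are available to account for this difference between the two fluorinated rings.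

The change from compound 2 to compound 4 alters both the number of fluorines and where they sit, so these compounds cannot show which of the two goes with the step. They also leave open how the number would respond to a chlorine, a methoxy group or an amine on this ring, or to a longer chain carrying the ring.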